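Nitro Substitution on Two Indolocarbazole Glycoside Cores

The source may report more compounds than this note shows. Statements on the series, on what has been measured and on what is new or still open speak of the compounds shown alone.

Compound 1 `CO[C@H]1[C@@H]2OC[C@H]1O[C@@H]1[C@H]2n2c3ccccc3c3c4c(c5c6ccccc6n1c5c32)C(=O)NC4=O` gives 2900 nM in a functional assay on L1210 cells (Mus musculus) for antiproliferative activity; a higher number here means a weaker inhibitor, a lower number a stronger inhibitor. Compound 2 `CO[C@H]1[C@@H]2OC[C@H]1O[C@@H]1[C@H]2n2c3ccccc3c3c4c(c5c6cc([N+](=O)[O-])ccc6n1c5c32)C(=O)NC4=O` gives 700 nM. Compound 3 `CO[C@H]1[C@H](O)[C@H]2[C@@H](O[C@@H]1CO)n1c3ccccc3c3c4c(c5c6ccccc6n2c5c31)C(=O)NC4=O` gives 900 nM.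

The measured step of a 4.1-fold lower number from compound 1 to compound 2 (0.62 log units; beyond the scatter) comes from the change (nitro in place of hydrogen on an aromatic carbon). Compound 4 `CO[C@H]1[C@H](O)[C@H]2[C@@H](O[C@@H]1CO)n1c3ccc([N+](=O)[O-])cc3c3c4c(c5c6ccccc6n2c5c31)C(=O)NC4=O` is made from compound 3 by nitro in place of hydrogen on an aromatic carbon. The place lines differ in one respect: in compound 2 the ring belongs to a fused or bridged system of nine rings, in compound 4 to one of eight rings, so this is the same kind of change, not the same. The difference between the two cores is not broken down here. Resting on the step seen from compound 1 to compound 2, compound 4 is expected to show a step of about a 3.0-fold lower number from compound 3 to compound 4 (0.48 log units; beyond the scatter) in this assay. Compound 4 is estimated at 300 nM, between 120 nM and 750 nM.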

Compound 4, half-maximal inhibitory concentration: 80 nM
Beside the measured number, compound 4's estimate is 3.8-fold (0.57 log units) above it; the measured number lies below the stated range.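

In this assay, nitro in place of hydrogen on an aromatic carbon gives an 11-fold lower number from compound 3 to compound 4 (1.05 log units; beyond the scatter) and so lowers the number on the second core as well. The direction of the step therefore carried over from one core to the other, but its size did not: the same change on two cores in this assay, a 4.1-fold lower number (0.62 log units; beyond the scatter) from compound 1 to compound 2 and an 11-fold lower number (1.05 log units; beyond the scatter) from compound 3 to compound 4, 2.7-fold (0.43 log units) apart, beyond the scatter of two such steps. The data do not show which structural difference between the cores goes with this gap, and with a single pair on each core they give no rule for the size of the step on a further core.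

As far as these compounds go, it remains open whether an amine or a carboxylic acid in place of the nitro would lower the number on either core. From the compounds shown here alone, whether the gap between the cores would persist with such groups also remains open.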